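The source may report more compounds than this note shows. Statements on the series, on what has been measured and on what is new or still open speak of the compounds shown alone.

Measured compounds:
Compound 1, `CO/C(O)=C1\C(C)=NC(C)=C(C(=O)OCCCN2C(=O)c3ccccc3S2(=O)=O)C1c1cccc(Cl)c1Cl`: in a functional assay on aorta with Voltage-dependent L-type calcium channel subunit alpha-1C (Oryctolagus cuniculus) as the target (on this read-out lower numbers stand for a shorter-lived compound and higher numbers for a longer-lived compound), compound 1 gives 0.283 h.
Compound 2, `CC1=NC(C)=C(C(=O)OCCCN2C(=O)c3ccccc3S2(=O)=O)C(c2cccc(Cl)c2Cl)/C1=C(\O)OC(C)C`: in this assay compound 2 gives 0.185 h.
Compound 3, `CO/C(O)=C1\C(C)=NC(C)=C(C(=O)OCCCN2C(=O)c3ccccc3S2(=O)=O)C1c1ccccc1Cl`: in this assay compound 3 gives 0.0867 h.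

Compound 4, `CC1=NC(C)=C(C(=O)OCCCN2C(=O)c3ccccc3S2(=O)=O)C(c2ccccc2Cl)/C1=C(\O)OC(C)C`, has not yet been measured. It is related to compound 3 in the same way that compound 2 is related to compound 1: the change is isopropyl in place of methyl on an oxygen on an unsaturated carbon in the first pair and isopropyl in place of methyl on an oxygen on an unsaturated carbon in the second, and the two descriptions of the place of the change are identical word for word, so it is the same change on two different cores. The two cores themselves differ by hydrogen in place of chloro on an aromatic carbon, and that difference brought a 3.3-fold lower number from compound 1 to compound 3 (0.51 log units; beyond the scatter).

Where the change has already been measured, it gave a 1.5-fold lower number from compound 1 to compound 2 (0.18 log units; within the scatter). Compound 3 stands lowest of the three measured compounds in this assay, and both of its gaps to the others are beyond the scatter.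

For compound 4 the same change is expected to behave much as it did between compound 1 and compound 2, because the step of a 1.5-fold lower number from compound 1 to compound 2 (0.18 log units; within the scatter) was small and within the scatter. Compound 4 is therefore expected to show a 1.4-fold lower number from compound 3 to compound 4 (0.16 log units; within the scatter), a step that would still be within the scatter. Compound 4 is estimated at 0.06 h in this assay, with a likely range from 0.03 h to 0.13 h.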

Compound 4, half-life: 0.08 h
Estimate against measurement, compound 4: 1.3-fold (0.12 log units) below, within the range that was stated.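

In this assay, the change from methoxy to isopropoxy gives a 1.1-fold lower number from compound 3 to compound 4 (0.03 log units; within the scatter), so on neither core does it move the half-life beyond the scatter, and the two steps agree: the same change on two cores in this assay, a 1.5-fold lower number (0.18 log units; within the scatter) from compound 1 to compound 2 and a 1.1-fold lower number (0.03 log units; within the scatter) from compound 3 to compound 4, 1.4-fold (0.15 log units) apart, within the scatter of two such steps.

The loss of chloro from the aromatic ring, read on the isopropoxy compounds, gives a 2.3-fold lower number from compound 2 to compound 4 (0.36 log units; beyond the scatter), which is beyond the scatter and matches the same replacement read on the methoxy compounds: the same change on two cores in this assay, a 3.3-fold lower number (0.51 log units; beyond the scatter) from compound 1 to compound 3 and a 2.3-fold lower number (0.36 log units; beyond the scatter) from compound 2 to compound 4, 1.4-fold (0.15 log units) apart, within the scatter of two such steps.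

Together these steps show that, across these four compounds, the two changes carried from one core to the other without a detectable shift in size, but they rest on just two cores that differ in a single chloro, and they do not show that the methoxy to isopropoxy change would stay this small on a core differing in any other place.

The compounds shown leave open how the half-life would respond to an ethyl group, a tert-butyl group or a longer chain on that oxygen. They also leave open whether a fluoro or a nitrile in place of chloro on an aromatic carbon would leave the methoxy to isopropoxy change as small as it is here.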